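Defining the stereocentres in a bis-carbamate curcuminoid ester

A few compounds are considered here, and "the series" means these few. Any claim that something is new, unique, unknown or untested is made for them only; others in the source may bear on it.

Three compounds share a symmetric core carrying two amino-acid ester arms. Compound 1, `COc1cc(/C=C/C(=O)/C=C(O)/C=C/c2ccc(OC(=O)[C@H](C)NC(=O)OC(C)(C)C)c(OC)c2)ccc1OC(=O)[C@H](C)NC(=O)OC(C)(C)C`, gives 6% in a functional assay on the whole organism (strain Wistar) for inhibition, with Rattus norvegicus as the target, read by paw edema, with a stated time of 1 h, at a dose of 10 mg/kg by the intraperitoneal route; a lower number here means less inhibition, a higher number more inhibition at the dose given (going by the name of the read-out). Compound 2, `COc1cc(/C=C/C(=O)/C=C(O)/C=C/c2ccc(OC(=O)[C@H](CCSC)NC(=O)OC(C)(C)C)c(OC)c2)ccc1OC(=O)[C@H](CCSC)NC(=O)OC(C)(C)C`, gives 34%. Compound 3, `COc1cc(/C=C/C(=O)/C=C(O)/C=C/c2ccc(OC(=O)C(C)NC(=O)OCc3ccccc3)c(OC)c2)ccc1OC(=O)C(C)NC(=O)OCc1ccccc1`, gives 72%, the highest of the three; compound 2 sits well below it, beyond the scatter, and compound 1 sits lower still, also beyond the scatter. Among the measured compounds shown here, no step between two measured compounds that differ in a single place is available, so the values can only be compared as they stand.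

Compound 4, `COc1cc(/C=C/C(=O)/C=C(O)/C=C/c2ccc(OC(=O)[C@@H](C)NC(=O)OCc3ccccc3)c(OC)c2)ccc1OC(=O)[C@@H](C)NC(=O)OCc1ccccc1`, keeps every atom and bond of compound 3; the difference is confined to how two centres are drawn: the two compounds have the same atoms and bonds; at least one stereo element is drawn with a configuration in one of them and without one in the other: 2 of 5 stereo elements differ; a stereocentre at a saturated chain carbon is drawn without a configuration in compound 3 and R in compound 4; a stereocentre at a saturated chain carbon is drawn without a configuration in compound 3 and R in compound 4

For the measured compounds named here, with no measured step of this kind to rest on, the change is expected to move the number only modestly, and if anywhere, downward, since compound 3 is drawn as an unresolved mixture while compound 4 is a single form. The estimated step of a number 10 percentage points lower from compound 3 to compound 4 (within the scatter) is within the scatter. Compound 4 is therefore expected to give about 62%, with a range from 35% to 85%.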

Compound 4, a percentage reported as inhibition, in the whole organism at one dose (the size of the read-out at that dose, not a potency): 82%
Compound 4: the middle estimate sits 20 percentage points below what was measured; measured number inside the range.
By their numbers in this assay, from the lowest: compound 1; then compound 2; then compounds 3 and 4 (each within the scatter of the next).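

Among the compounds shown here, this pair gives the first comparison in the set that rests on a single kind of change. In this assay, the step is a number 10 percentage points higher from compound 3 to compound 4 (within the scatter), so the number read for the form with both saturated chain carbons drawn as R cannot be told apart from the number read for the form drawn without a configuration. The high reading is therefore not confined to a drawing with undefined stereocentres, and it holds for a form in which both centres are defined, although the data give no cause for the reading and the only structural distinction available is this: the fact that one of compounds 3 and 4 is drawn with a defined configuration and the other without, at the place where they differ

From the compounds shown here alone, what the form with both centres drawn S would give at these positions remains open, as does whether a mixed form with one R and one S centre would read the same. Also open is whether a free amine in place of the benzyl carbamate would keep the reading, and since this read-out comes from a single dose at a single time, it gives no measure of potency for any of these compounds.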